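Swapping one aryl group on a shared core

This account rests on a few compounds, and the source may have more. Where it says the series, first, only, none or still open, it means among the compounds named here.

Compound 1 `COc1ccc(-c2cc3c(cn2)[nH]c(=O)n3-c2cc(OC)c(OC)c(OC)c2)cc1` gives 1210 nM
Compound 2 `COc1ccc(-c2cc3c(cn2)[nH]c(=O)n3-c2cc(OC)c(OC)c(OC)c2)cn1` gives 870 nM

Both compounds share one core and were tested in a functional assay on HeLa cells (Homo sapiens) for antiproliferative activity, read by MTT assay, with a stated time of 48 h (a higher number here means a weaker inhibitor, a lower number a stronger inhibitor), as the measure of growth inhibition. In this assay, compound 2 at 870 nM lies within the scatter of compound 1, so the pair cannot be ranked. Among the measured compounds shown here, the next compound, compound 3 `COc1ccc(-c2cc3c(cn2)[nH]c(=O)n3-c2cc(OC)c(OC)c(OC)c2)cc1C`, keeps the core but carries 4-methoxy-3-methylphenyl in place of 6-methoxypyridin-3-yl on an aromatic carbon as its single change.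

For the measured compounds named here, only one measured step bears on this change. Replacing 4-methoxyphenyl with 6-methoxypyridin-3-yl gave a 1.4-fold lower number from compound 1 to compound 2 (0.14 log units; within the scatter) and so offers little reason to expect much from returning to a carbon-only ring. Going by the values given here, the extra methyl group is untested, as no measured compound carries it, so the range must stay wide. In this assay no step beyond the scatter is expected, in either direction. The expected change is a 1.1-fold lower number from compound 2 to compound 3 (0.04 log units; within the scatter) and rests on this single pair. For compound 3 the estimate is 800 nM with an expected range of 250 nM to 2500 nM for repeated measurements.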

Compound 3, half-maximal inhibitory concentration: 1410 nM
Estimate against measurement, compound 3: 1.8-fold (0.25 log units) below; low and high end bracket the measured number.
By their numbers in this assay, from the lowest: compounds 2, 1 and 3 (each within the scatter of the next).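

In this assay, the methyl group gets its first test here: adding it to the 4-methoxyphenyl ring of compound 1 gives a 1.2-fold higher number from compound 1 to compound 3 (0.07 log units; within the scatter), so this small addition produces no readable shift in this pair. The swap of 6-methoxypyridin-3-yl for 4-methoxy-3-methylphenyl gives a 1.6-fold higher number from compound 2 to compound 3 (0.21 log units; within the scatter), which means that this change of ring, with its ring nitrogen gone and a methyl group added, also stays inside the noise and the three compounds cannot be ranked. No measured information accompanies these numbers to explain them.

From the compounds shown here alone, all three groups at this position are six-membered aromatic rings carrying a methoxy group, so it remains open whether a group of another kind, such as an amine or a carboxylic acid in place of the methoxy, or a longer chain such as butoxy, would produce a step beyond the scatter. Going by these compounds, it is also open whether the methyl group would behave the same way on the pyridine ring, as in 6-methoxy-5-methylpyridin-3-yl, which would complete the set of four combinations.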